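Lengthening the Tail: From Compound 3 to Compound 4

The source may report more compounds than this note shows. Statements on the series, on what has been measured and on what is new or still open speak of the compounds shown alone.

Three compounds were measured in a functional assay on A549 cells (Homo sapiens) for inhibition, read by CCK-8 assay, with a stated time of 72 h, tested at 10 uM; on this read-out higher numbers stand for a stronger effect at the one concentration tested and lower numbers for a weaker effect:

compound 1, `CN(C)C(=O)c1cc2cnc(Nc3ccc(C(=O)NCCCCN=C=S)cc3O)nc2n1C1CCCC1`, gives 41.7%
compound 2, `CN(C)C(=O)c1cc2cnc(Nc3ccc(C(=O)NCCCCCN=C=S)cc3O)nc2n1C1CCCC1`, gives 30.7%
compound 3, `CN(C)C(=O)c1cc2cnc(Nc3ccc(NC(=O)CCCCCN=C=S)cc3)nc2n1C1CCCC1`, gives 100%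

Compound 1 and compound 2 share one core; the difference between that core and the core of compound 3 is not broken down here. The change from compound 1 to compound 2 is a group of 4 heavy atoms (2 carbon, 1 nitrogen, 1 sulfur; no ring) in place of a group of 3 heavy atoms (1 carbon, 1 nitrogen, 1 sulfur; no ring), on a saturated chain carbon, four bonds along the chain from an amide-type nitrogen, and it gave a number 11 percentage points lower from compound 1 to compound 2 (beyond the scatter).

Compound 4, `CN(C)C(=O)c1cc2cnc(Nc3ccc(NC(=O)CCCCCCN=C=S)cc3)nc2n1C1CCCC1`, has not yet been measured in this assay. It differs from compound 3 by a group of 4 heavy atoms (2 carbon, 1 nitrogen, 1 sulfur; no ring) in place of a group of 3 heavy atoms (1 carbon, 1 nitrogen, 1 sulfur; no ring), on a saturated chain carbon, five bonds along the chain from a carbonyl carbon. The surroundings are not identical: in compound 1 the change sits four bonds along the chain from an amide-type nitrogen, in compound 3 five bonds along the chain from a carbonyl carbon, so this is the same kind of change rather than the same one. Compound 3 is the highest of the three, and its number leaves no room for an upward step.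

Because the earlier step of a number 11 percentage points lower from compound 1 to compound 2 (beyond the scatter) was a modest fall, compound 4 is expected to drop by a number 15 percentage points lower from compound 3 to compound 4 (beyond the scatter). Compound 4 is estimated at 85%, with a range from 55% to 100%.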

Compound 4, a percentage reported as inhibition, at one concentration (the size of the read-out at that concentration, not a potency): 102%
The estimate for compound 4 lay 17 percentage points below the measured number; measured number above the stated range.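

In this assay, the same kind of change on the core of compound 3, a group of 4 heavy atoms in place of a group of 3 heavy atoms, gave a number 2 percentage points higher from compound 3 to compound 4 (within the scatter). Set beside the earlier step on the core of compound 1, this result does not separate the two cores: the same change on two cores in this assay, a number 11 percentage points lower (beyond the scatter) from compound 1 to compound 2 and a number 2 percentage points higher (within the scatter) from compound 3 to compound 4, 13 percentage points apart, within the scatter of two such steps. Within the data shown here, it does not show that the change acts alike on both cores, as there are only two steps, their surroundings differ, and compound 3 already stands at 100% at a single concentration, which gives no potency.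

The compounds shown leave open whether a longer chain on the core of compound 3 would hold this level, and whether an amine or a carboxylic acid in place of the group at the chain end would do the same. They also leave open how compound 3 and compound 4 compare at lower concentrations.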